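The source may report more compounds than this note shows. Statements on the series, on what has been measured and on what is new or still open speak of the compounds shown alone.

Measured compounds:
compound 1 `Clc1ccc(Oc2ccc3nc(-c4ccc(OC5CCNCC5)cc4)oc3c2)cc1`, in an assay on isolated protein for inhibition of advanced glycosylation end product-specific receptor (Homo sapiens), read by FRET, with stated times of 30 min and 1 h, tested at 4 uM (on this read-out lower numbers stand for less inhibition and higher numbers for more inhibition at the one concentration tested (going by the name of the read-out)), compound 1 gives 20.6%
compound 2 `CCN1CCC(Oc2ccc(-c3nc4ccc(Oc5ccc(Cl)cc5)cc4o3)cc2)CC1`, in this assay compound 2 gives 15.3%
compound 3 `CCN1CCC(COc2ccc(-c3nc4ccc(Oc5ccc(Cl)cc5)cc4o3)cc2)CC1`, in this assay compound 3 gives 2.1%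

Compound 3 stands lowest of the three numbers in this assay; its nearest neighbour is compound 2, the furthest is compound 1, and both gaps are beyond the scatter. The steps that lead to compound 3 are a number 18.5 percentage points lower from compound 1 to compound 3 (beyond the scatter) and a number 13.2 percentage points lower from compound 2 to compound 3 (beyond the scatter), while the step of a number 5.3 percentage points lower from compound 1 to compound 2 (within the scatter) is within the scatter. Compound 4 `Clc1ccc(Oc2ccc3nc(-c4ccc(OCCCN5CCCC5)cc4)oc3c2)cc1` differs from compound 3 in one place: 2-(pyrrolidin-1-yl)ethyl in place of 1-ethylpiperidin-4-yl on a saturated chain carbon bound to an oxygen on an aromatic ring.

Within the data shown here, no measured step changes the ring or chain in this way, so the two steps into compound 3 are the only guide, and they show the lowest number where the chain between the oxygen and the ring is longest. Compound 4 is therefore expected to stay near compound 3, with an expected step of a number 3.9 percentage points higher from compound 3 to compound 4 (within the scatter) not beyond the scatter. For compound 4 the estimate in this assay is 6%, ranging from -6% to 20%.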

Compound 4, a percentage reported as inhibition, at one concentration (the size of the read-out at that concentration, not a potency): "not active" (no number reported)
Compound 4 has no reported number here; there is nothing to compare the estimate with.
By their numbers in this assay, from the lowest: compound 3; then compounds 2 and 1 (each within the scatter of the next).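

In this assay, among these compounds, compound 4 is reported as not active without a number, so no step from compound 3 or any other compound can be read. The compounds shown leave open how 3-(pyrrolidin-1-yl)propyl compares numerically with (1-ethylpiperidin-4-yl)methyl, and no measurement here bears on this result.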